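A few compounds are considered here, and "the series" means these few. Any claim that something is new, unique, unknown or untested is made for them only; others in the source may bear on it.

Compound 1 `CCN(CC)S(=O)(=O)c1ccc(S(=O)(=O)N2CCC[C@@H](C(=O)N(C)C(C)C)C2)cc1` — in a functional assay on MIA PaCa-2 cells (Homo sapiens) for inhibition, read by MTT assay, with a stated time of 3 days (a lower number here means a stronger inhibitor, a higher number a weaker inhibitor), compound 1 gives 1400 nM.
Compound 2 `CCN1CC(NC(=O)[C@@H]2CCCN(S(=O)(=O)c3ccc(S(=O)(=O)N(CC)CC)cc3)C2)C1` — in this assay compound 2 gives > 10000 nM, which is a limit of the assay rather than a number.

Compound 2 thus stands at the limit of > 10000 nM in this assay, at which 1 of the 2 values shown sits, so only a range is known for it, and it cannot be placed in order against compound 1 beyond the fact that it is the weaker of the two. Going by the values given here, the one measured step bears directly on the question: an at least 7.1-fold higher number from compound 1 to compound 2 (0.85 log units; beyond the scatter). The move from compound 2 to compound 3 `CCN(CC)S(=O)(=O)c1ccc(S(=O)(=O)N2CCC[C@@H](C(=O)NC)C2)cc1` undoes the larger amide substituent: methyl in place of 1-ethylazetidin-3-yl on an amide-type nitrogen. Because the bulkier (1-ethylazetidin-3-yl)amino in compound 2 gave > 10000 nM where the smaller isopropyl(methyl)amino in compound 1 gave 1400 nM, the return to a small methylamino group in compound 3 is expected to bring the number back down toward the level of compound 1, though a methylcarbamoyl is not the same as the isopropyl(methyl)amino amide and the exact size is uncertain. Compound 3 is therefore estimated at 2500 nM in this assay, with a likely range from 700 nM to 10000 nM. That estimate implies a step of an at least 4.0-fold lower number from compound 2 to compound 3 (0.60 log units; beyond the scatter).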

Compound 3, half-maximal inhibitory concentration: 2000 nM
Beside the measured number, compound 3's estimate is 1.3-fold (0.10 log units) above it, within the range that was stated.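

On the amide-type nitrogen whose other neighbour is the carbonyl carbon, the exchange of 1-ethylazetidin-3-yl for methyl recovers activity in this assay (an at least 5.0-fold lower number from compound 2 to compound 3 (0.69 log units; beyond the scatter)). The weak result therefore goes with the 1-ethylazetidin-3-yl group and not with the amide hydrogen, which is present in both of these compounds. The isopropyl group of compound 1 also proves dispensable at this level of activity, since the change to hydrogen on that nitrogen stays within the scatter (a 1.4-fold higher number from compound 1 to compound 3 (0.15 log units; within the scatter)), while the full size of the loss stays unknown, as the value of compound 2 is a limit of the assay and not a number: the limit of > 10000 nM in this assay, at which 1 of the 3 values shown sits.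

What the compounds leave open is which part of 1-ethylazetidin-3-yl goes with the loss: its ring, its ethyl group or its ring nitrogen, a question that a cyclobutyl group or a longer chain such as n-butyl on the same nitrogen would address. Also open, from the compounds shown here alone, is whether any group on this nitrogen, such as a cyclopropyl or a small ether chain, would take the number clearly below that of compound 1 and compound 3.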